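One Aryl Swap on a Weakly Active Compound

The compounds below may be only part of what the source reports. "The series", "measured", "known", "first", "only" and "open" are said of these compounds alone.

Compound 1 (`Cc1ccc(S(=O)(=O)/C(=C/c2sccc2C)C(=O)c2ccc(Cl)cc2)cc1`) gives 10000 nM in a functional assay on DU-145 cells (Homo sapiens) for inhibition, read by trypan blue exclusion, with a stated time of 96 h (on this read-out higher numbers stand for weaker inhibition of growth and lower numbers for stronger inhibition of growth), and compound 2 (`COc1cc(/C=C(/Sc2ccc(Br)cc2)C(=O)c2ccc(Br)cc2)ccc1O`) gives 1000 nM there. Compound 1 thus stands at the higher of the two numbers, which means the weaker inhibition of growth, and the gap between them lies beyond the usual scatter.

Compound 3 (`COc1ccccc1/C=C(\C(=O)c1ccc(Cl)cc1)S(=O)(=O)c1ccc(C)cc1`) has not yet been measured. It departs from compound 1 by one structural change (2-methoxyphenyl in place of 3-methylthiophen-2-yl on a double-bonded chain carbon bound to a double-bonded chain carbon), with 2-methoxyphenyl in place of 3-methylthiophen-2-yl on a double-bonded chain carbon bound to a double-bonded chain carbon.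

Within the data shown here, no measured pair isolates this change, so the expectation starts from compound 1 at 10000 nM and leans only slightly towards compound 2 at 1000 nM on the scale. In this assay a small step towards a lower number is expected, with a 1.7-fold lower number from compound 1 to compound 3 (0.22 log units; within the scatter) as the estimated size, which would not lie beyond the scatter. For compound 3 the estimate is 6000 nM with an expected range from 1500 nM to 20000 nM on this read-out.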

Compound 3, concentration for 50% growth inhibition: 1000 nM
Estimate against measurement, compound 3: 6.0-fold (0.78 log units) above; measured number below the stated range.
By their numbers in this assay, from the lowest: compounds 2 and 3 (each within the scatter of the next); then compound 1.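

Among these compounds, replacing 3-methylthiophen-2-yl with 2-methoxyphenyl on a double-bonded chain carbon bound to a double-bonded chain carbon gives a 10-fold lower number from compound 1 to compound 3 (1.00 log units; beyond the scatter) in this assay, the first one-place comparison in this set, and it shows that the group at this position can alter inhibition of growth while the rest of compound 1 stays unchanged. The two groups have the same counts of hydrogen-bond donors and acceptors and carry no net charge, so the step comes with a different set of differences: more heavy atoms, oxygen in place of sulfur, and a six-membered aromatic ring of carbon only in place of a five-membered aromatic ring with one hetero atom. No measured evidence here explains why this change alters the read-out.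

This single step cannot separate the contribution of the methoxy group from that of the six-membered aromatic ring, and the compounds shown do not test either one alone. An unsubstituted phenyl group at this place would address that question, while a 2-aminophenyl or 2-hydroxyphenyl group would show whether the methoxy group can be exchanged.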